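Changing one aryl group: what cytotoxicity to expect

A few compounds are considered here, and "the series" means these few. Any claim that something is new, unique, unknown or untested is made for them only; others in the source may bear on it.

Compound 1 `COc1cccc(N2CCN(CC(=O)N3CCN(c4nnc(-c5ccccc5)c(-c5ccccc5)n4)CC3)CC2)c1` gives 361000 nM
Compound 2 `COc1ccc(N2CCN(CC(=O)N3CCN(c4nnc(-c5ccccc5)c(-c5ccccc5)n4)CC3)CC2)cc1` gives > 910000 nM
Compound 3 `O=C(CN1CCN(c2ccccc2Cl)CC1)N1CCN(c2nnc(-c3ccc(Cl)cc3)c(-c3ccc(Cl)cc3)n2)CC1` gives > 803000 nM

In an ADME assay on NIH3T3 cells (Mus musculus) for cytotoxicity, read by MTT assay, with a stated time of 24 h (a lower number here means a stronger inhibitor, a higher number a weaker inhibitor), compound 1 gives 361000 nM. Compound 2 reaches only a limit of the assay, > 910000 nM. Compound 3 likewise shows only a limit, > 803000 nM, so it sits at the weak end of what has been measured. Compound 4 `O=C(CN1CCN(c2ccc([N+](=O)[O-])cc2)CC1)N1CCN(c2nnc(-c3ccc(Cl)cc3)c(-c3ccc(Cl)cc3)n2)CC1` differs from compound 3 in one place: 4-nitrophenyl in place of 2-chlorophenyl on an amine nitrogen in a ring. For the measured compounds named here, the one measured step at the same place, an at least 2.5-fold higher number from compound 1 to compound 2 (0.40 log units; beyond the scatter), moved the number upward, and compound 3 already stands at a limit, as the limit of > 803000 nM in this assay, at which 1 of the 3 values shown sits, shows. Compound 4 is therefore expected to remain at or near a limit, a step that the limit leaves unreadable from compound 3 to compound 4. The estimate for compound 4 is 900000 nM, between 300000 nM and 3000000 nM.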

Compound 4, half-maximal inhibitory concentration: > 789000 nM
Compound 4 was reported as a limit; the forecaster's own chance of this, stated with the estimate: 70%; the middle value lies beyond the limit too.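

Compound 3 and compound 4 are both reported only as limits of the assay, so the step between them cannot be read. The compounds shown leave open whether 4-nitrophenyl or 2-chlorophenyl gives the higher number.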